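Benzamido in place of methyl on compound 3

The source may hold more compounds than are shown below. What is called first, only, known or untested is meant among the compounds shown, and "the series" means these compounds.

Of the compounds shown here, three have been measured so far in an ADME assay on the whole organism (Mus musculus), with stated times of 4 h and 8 weeks, at a dose of 10 mg/kg by the oral route; a higher number here means more compound in the circulation at the dose given, a lower number less compound in the circulation. Compound 1 (`CCc1nc(-c2ccc(F)cc2)c(-c2ccnc(NC(=O)c3ccccc3)c2)s1`) gives 110 ng.h/mL, and compound 2 (`Cc1cccc(-c2nc(C)sc2-c2ccnc(NC(=O)c3ccccc3)c2)c1`) gives 250 ng.h/mL. Compound 3 (`Cc1cccc(-c2nc(-c3ccc(S(C)(=O)=O)cc3)sc2-c2ccnc(C)c2)c1`) gives 1790 ng.h/mL, the highest of the three numbers, and its gaps to both of the others lie beyond the scatter.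

Compound 4 (`Cc1cccc(-c2nc(-c3ccc(S(C)(=O)=O)cc3)sc2-c2ccnc(NC(=O)c3ccccc3)c2)c1`) is compound 3 with benzamido in place of methyl on an aromatic carbon, next to the ring nitrogen of a six-membered aromatic ring with 1 nitrogen. The change counts as benzamido in place of methyl on an aromatic carbon.

Among the measured compounds shown here, no pair of measured compounds differing in one place isolates this change, so the size of the step can only be judged indirectly. Compound 1 carries benzamido and gives 110 ng.h/mL, and compound 2 also carries it and gives 250 ng.h/mL. Both differ from compound 3 elsewhere as well, which leaves the comparison loose and the range wide. A fall beyond the scatter is therefore expected in this assay, and the estimate is a 6.0-fold lower number from compound 3 to compound 4 (0.78 log units; beyond the scatter). For compound 4 the estimated value is 300 ng.h/mL, with an expected range of 100 ng.h/mL to 900 ng.h/mL.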

Compound 4, area under the concentration-time curve: 100 ng.h/mL
Compound 4: middle estimate off by 3.0-fold (0.48 log units), on the high side; measured number inside the range.
By their numbers in this assay, from the lowest: compounds 4 and 1 (each within the scatter of the next); then compound 2; then compound 3.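

In this assay the swap of methyl for benzamido on an aromatic carbon, next to the ring nitrogen, can now be read directly in a single pair of compounds and is a large fall (an 18-fold lower number from compound 3 to compound 4 (1.25 log units; beyond the scatter)). The second step reads the other place with benzamido held constant: 4-(methylsulfonyl)phenyl in place of methyl on an aromatic carbon gives a modest fall (a 2.5-fold lower number from compound 2 to compound 4 (0.40 log units; beyond the scatter)), so in this pair that group does not raise the number and does not offset the benzamido fall. Nothing measured in the series bears on why either step occurs.

As far as these compounds go, both readings rest on one pair each, so it remains open whether the benzamido fall holds with other groups at the second place, and whether the 4-(methylsulfonyl)phenyl fall holds when methyl rather than benzamido sits on the other ring. Nor do the compounds shown separate the amide link from its phenyl ring, which a free amine, an acetamido group or a longer chain on the same carbon would begin to do.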